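The source may hold more compounds than are shown below. What is called first, only, known or untested is meant among the compounds shown, and "the series" means these compounds.

In a functional assay on the whole organism with Mus musculus as the target, at a dose of 100 mg/kg by the intraperitoneal route (on this read-out higher numbers stand for more inhibition at the one dose given (going by the name of the read-out) and lower numbers for less inhibition), compound 1 `CCNC(=O)/C=C1\CCc2ccc(F)cc21` gives 100%, while compound 2 `O=C(/C=C1\CCc2ccc(F)cc21)N1CCCC1` gives 33%, the lowest of the two values shown. Within the data shown here, the only measured step, a number 67 percentage points lower from compound 1 to compound 2 (beyond the scatter), is the one that introduced the ring now being removed. Compound 3 `CCCNC(=O)/C=C1\CCc2ccc(F)cc21` differs from compound 2 by propylamino in place of pyrrolidin-1-yl on a carbonyl carbon. From the compounds shown here alone, since this change undoes the one kind of alteration seen to matter, a large rise is expected in this assay, a number 57 percentage points higher from compound 2 to compound 3 (beyond the scatter), though the propyl chain remains untested. Compound 3 is therefore estimated at 90%, within 60% to 100%.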

Compound 3, a percentage reported as inhibition, in the whole organism at one dose (the size of the read-out at that dose, not a potency): 100%
Beside the measured number, compound 3's estimate is 10 percentage points below it; the measured number falls inside the stated range.
By their numbers in this assay, from the lowest: compound 2; then compounds 1 and 3 (each within the scatter of the next).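

In this assay, propylamino in place of pyrrolidin-1-yl on the carbonyl carbon gives a number 67 percentage points higher from compound 2 to compound 3 (beyond the scatter), so the low number of compound 2 is not confined to a comparison with ethylamino. One more methyl on the open chain gives no change at the digits printed from compound 1 to compound 3 (within the scatter), so this position holds its number across these two open chains. Nothing measured here explains the difference between the ring and the open chains.

From the compounds shown here alone, whether the amide hydrogen or the open chain is what counts remains open, and a dimethylamino group could help separate the two. Going by these compounds, how a butyl chain or a piperidin-1-yl ring would behave at this carbonyl carbon also remains unknown.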